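A Methyl Removed: From Compound 3 to Compound 4

The source may report more compounds than this note shows. Statements on the series, on what has been measured and on what is new or still open speak of the compounds shown alone.

Going by the values given here, compound 3 `COc1cc(C)cc(-c2nn(CC#N)cc2-c2ccnc(-c3ccc(N(C)C)cc3)c2)c1` carries the highest of the three numbers so far: in a functional assay on SK-MEL-2 cells (Homo sapiens) for inhibition, read by sulforhodamine B assay, with a stated time of 48 h (a higher number here means a weaker inhibitor of growth, a lower number a stronger inhibitor of growth), compound 3 gives 45500 nM. Compound 1 `COc1cc(C)cc(-c2nn(CC#N)cc2-c2ccc(-c3cccc(C(C)=O)c3)nc2)c1` lies within the scatter of it, giving 41300 nM in this assay. Compound 2 `Cc1cc(O)cc(-c2nn(CC#N)cc2-c2ccnc(-c3ccc(Oc4ccccc4)cc3)c2)c1` stands well apart, giving 11700 nM in this assay, yet it differs from compound 3 in two places, so its number alone cannot be tied to either. Compound 4 `Cc1cc(O)cc(-c2nn(CC#N)cc2-c2ccnc(-c3ccc(N(C)C)cc3)c2)c1` differs from compound 3 in one place: hydrogen in place of methyl on an oxygen on an aromatic ring. No such single step has been measured among these compounds. Compound 4 is expected to show a modest move to a lower number, a step of about a 1.8-fold lower number from compound 3 to compound 4 (0.26 log units; within the scatter) in this assay. The estimate for compound 4 is 25000 nM, with a range from 8000 nM to 70000 nM.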

Compound 4, concentration for total growth inhibition: 15800 nM
Beside the measured number, compound 4's estimate is 1.6-fold (0.20 log units) above it; the range from low to high includes it.
By their numbers in this assay, from the lowest: compounds 2 and 4 (each within the scatter of the next); then compounds 1 and 3 (each within the scatter of the next).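

In this assay, methoxy to hydroxy on the aromatic ring gives a 2.9-fold lower number from compound 3 to compound 4 (0.46 log units; beyond the scatter), the only single change shown that moves the number beyond the scatter. With the hydroxy kept, dimethylamino in place of phenoxy gives a 1.4-fold higher number from compound 2 to compound 4 (0.13 log units; within the scatter), so this swap shows no readable effect on that aromatic carbon. Nothing available accounts for either step. Going by these compounds, it remains open whether an ethoxy group or an amine in place of the hydroxy would keep the lower number. Also open, on these data alone, is whether methoxy to hydroxy gives a similar step with the other groups on the shared core.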